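The compounds below may be only part of what the source reports. "The series", "measured", "known", "first", "only" and "open" are said of these compounds alone.

Working notes on the series. The shared core carries an aryl group on its fused ring and, in most members, a 4-methoxybenzyl group on the ring nitrogen. Compound 1 `Cc1ccc(-c2ccc3c(c2)C(=O)C(=O)N3)cc1` lacks that benzyl group and bears 4-methylphenyl; in a functional assay on K562 cells (Homo sapiens) for antiproliferative activity, read by MTT assay, with a stated time of 48 h (on this read-out lower numbers stand for stronger inhibition and higher numbers for weaker inhibition), compound 1 gives only a limit, > 10000 nM (the limit of > 10000 nM in this assay, at which 1 of the 3 values shown sits). Compound 2 `COc1ccc(CN2C(=O)C(=O)c3cc(-c4cccc(OC)c4)ccc32)cc1`, with 3-methoxyphenyl and the benzyl group in place, gives 100 nM in this assay. Within the data shown here, compound 3 `COc1ccc(CN2C(=O)C(=O)c3cc(-c4ccc(F)c(Cl)c4)ccc32)cc1`, with 3-chloro-4-fluorophenyl, gives 380 nM and so stands at the higher of the two numbers, with compound 2 as its only numbered neighbour. The one measured move within the benzylated pair is a 3.8-fold higher number from compound 2 to compound 3 (0.58 log units; beyond the scatter).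

Compound 4 `COc1ccc(CN2C(=O)C(=O)c3cc(-c4ccc(C)cc4)ccc32)cc1` is the next member: 4-methylphenyl in place of 3-chloro-4-fluorophenyl on an aromatic carbon. Compound 4 is thus the benzylated counterpart of compound 1. Among the measured compounds shown here, the only measured step bearing on an exchange of the aryl group is a 3.8-fold higher number from compound 2 to compound 3 (0.58 log units; beyond the scatter), a modest shift between two aryl groups of this kind. For the measured compounds named here, no measured step addresses 4-methylphenyl on the benzylated core; compound 1 supplies only a limit. The estimated step of a 1.5-fold lower number from compound 3 to compound 4 (0.18 log units; within the scatter) is therefore expected to stay within the scatter, leaving the number between the two already seen. Compound 4 is estimated at 250 nM, with a range from 80 nM to 800 nM.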

Compound 4, half-maximal inhibitory concentration: 400 nM
Compound 4: middle estimate off by 1.6-fold (0.20 log units), on the low side; the range from low to high includes it.
By their numbers in this assay, from the lowest: compound 2; then compounds 3 and 4 (each within the scatter of the next). At a limit, above all of these: compound 1.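

In this assay, 4-methylphenyl in place of 3-chloro-4-fluorophenyl on an aromatic carbon gives a 1.1-fold higher number from compound 3 to compound 4 (0.02 log units; within the scatter), so this read-out does not separate these two aryl groups. Set against 3-methoxyphenyl, the same 4-methylphenyl group gives a 4.0-fold higher number from compound 2 to compound 4 (0.60 log units; beyond the scatter), a second move away from 3-methoxyphenyl beyond the scatter and in the same direction as a 3.8-fold higher number from compound 2 to compound 3 (0.58 log units; beyond the scatter), which leaves 3-methoxyphenyl as the one aryl group shown that stands apart from the other two. With 4-methylphenyl held fixed, the series now has a direct comparison at the ring nitrogen, where 4-methoxybenzyl in place of hydrogen gives an at least 25-fold lower number from compound 1 to compound 4 (1.39 log units; beyond the scatter), and this step rests on the limit of compound 1: the limit of > 10000 nM in this assay, at which 1 of the 4 values shown sits.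

Going by these compounds, it remains open whether the separate standing of 3-methoxyphenyl belongs to the methoxy group or to its place on the ring, and what 4-methoxyphenyl or an unsubstituted phenyl would give on the benzylated core. On these data alone, what other groups on the ring nitrogen would give, such as an unsubstituted benzyl, a longer alkyl chain or a chain ending in an amine, also remains open.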